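This account rests on a few compounds, and the source may have more. Where it says the series, first, only, none or still open, it means among the compounds named here.

Within the data shown here, compound 2 `CNC(=O)/C=C/c1ccc2noc(-c3ccccc3)c2c1` gives 42600 nM in an assay for inhibition of inositol hexakisphosphate kinase 3 (Homo sapiens), read by colorimetric assay, coupled enzyme assay and malachite green, with a stated time of 120 min, in the presence of a further agent that is not named here (on this read-out higher numbers stand for weaker inhibition and lower numbers for stronger inhibition), the higher of the two numbers measured so far; compound 1 `COC(=O)/C=C/c1ccc2noc(-c3ccccc3)c2c1` gives 12100 nM, and a 3.5-fold higher number from compound 1 to compound 2 (0.55 log units; beyond the scatter) is the only measured step. Compound 3 `CNC(=O)c1ccc2noc(-c3ccccc3)c2c1` differs from compound 2 by methylcarbamoyl in place of 2-(methylcarbamoyl)ethenyl on an aromatic carbon. Among the measured compounds shown here, that change shortens the attachment to the shared core rather than altering the end group, so the one measured step does not bear on it directly, and no direction beyond the scatter can be argued from the data. Compound 3 is estimated at 50000 nM, ranging from 12000 nM to 200000 nM, an expected step of a 1.2-fold higher number from compound 2 to compound 3 (0.07 log units; within the scatter).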

Compound 3, half-maximal inhibitory concentration: 6830 nM
Beside the measured number, compound 3's estimate is 7.3-fold (0.86 log units) above it, outside the stated range (below it).
By their numbers in this assay, from the lowest: compounds 3 and 1 (each within the scatter of the next); then compound 2.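

In this assay, shortening the attachment on this aromatic carbon, with the amide end kept, gives a 6.2-fold lower number from compound 2 to compound 3 (0.79 log units; beyond the scatter), so the ethenyl link is not needed for inhibition, something the earlier change at the end of the chain could not show. Set against the ester, the shortened amide gives a 1.8-fold lower number from compound 1 to compound 3 (0.25 log units; within the scatter), so shortening offsets the loss seen on going from ester to amide. Nothing available explains these differences. Open, from the compounds shown here alone, is whether the end group still counts once the attachment is short: methoxycarbonyl, a carboxylic acid or an amine on this same aromatic carbon would test that.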